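Methoxy for methyl on a series stuck at the limit

This account rests on a few compounds, and the source may have more. Where it says the series, first, only, none or still open, it means among the compounds named here.

Measured in an assay on HEK293 cells for inhibition of transient receptor potential cation channel subfamily V member 1 (Homo sapiens), read by FLIPR, at pH 5.5; on this read-out higher numbers stand for weaker inhibition and lower numbers for stronger inhibition:
compound 1 `O=C(Nc1nc2ccc(F)cc2s1)N1CCN(c2ccc(Cl)nn2)CC1`: > 10000 nM
compound 2 `Cc1ccc(N2CCN(C(=O)Nc3ccc(OC(F)(F)F)cc3)CC2)nn1`: > 10000 nM
compound 3 `Cc1ccc(N2CCN(C(=O)Nc3nc4ccc(F)cc4s3)CC2)nn1`: > 10000 nM

Compound 3 stands only at a limit of this assay, > 10000 nM. The same holds for each of the other two values shown, so that (the limit of > 10000 nM in this assay, at which 3 of the 3 values shown sit). For the measured compounds named here, the single one-place step, a step that the two limits leave unreadable from compound 1 to compound 3, has both its ends at that limit and yields no size.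

Compound 4 `COc1ccc(N2CCN(C(=O)Nc3nc4ccc(F)cc4s3)CC2)nn1` differs from compound 3 by methoxy in place of methyl on an aromatic carbon. Going by the values given here, no measured pair separates a methoxy from a methyl, and nothing among the values shown points away from the limit. The step that the limit leaves unreadable from compound 3 to compound 4 is therefore expected to stay within the scatter. Compound 4 is estimated at 20000 nM, with a range from 5000 nM to 80000 nM, most likely reported again only as a limit.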

Compound 4, half-maximal inhibitory concentration: > 10000 nM
Compound 4 gave a limit, no number; the forecaster's own chance of this, stated with the estimate: 85%; the middle value does not contradict the limit.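

For the compounds shown here, compound 4 again gives only a limit, so no step from compound 1 or compound 3 to compound 4 can be read. The compounds shown leave open how any of them ranks against the others, because every value sits at the same limit: the limit of > 10000 nM in this assay, at which 4 of the 4 values shown sit.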